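Hydroxyphenyl in place of cyanophenyl: cytotoxicity outlook

This account rests on a few compounds, and the source may have more. Where it says the series, first, only, none or still open, it means among the compounds named here.

Compound 1 `Cc1cc(-c2ccc(C#N)cc2)cn2c(CSCCc3ccccc3)cnc12` has been run in an ADME assay on HEL cells (Homo sapiens) for cytotoxicity, with a stated time of 3 days (on this read-out lower numbers stand for higher toxicity in this test and higher numbers for lower toxicity in this test), and returns only a limit of the assay, >= 20 ug/mL, so its position is known only as a range, not a number. Compound 2 `Cc1cc(-c2cccc(O)c2)c2ncc(CSCCc3ccccc3)n2c1` gives 20 ug/mL in this assay. Within the data shown here, no step between these two compounds has been computed; what the readings show is that the one number and the one limit sit at the same point, the limit being recorded as the limit of >= 20 ug/mL in this assay, at which 1 of the 2 values shown sits.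

Compound 3 `Cc1cc(-c2ccccc2O)cn2c(CSCCc3ccccc3)cnc12` has not yet been measured in this assay. Against compound 1 it differs in one place: 2-hydroxyphenyl in place of 4-cyanophenyl on an aromatic carbon. Among the measured compounds shown here, no measured step is available for this kind of change. Across the two compounds seen so far, nothing beyond the scatter is evident, so compound 3 is expected to land at 20 ug/mL, with a range from 10 ug/mL to 40 ug/mL. The step from compound 1 to compound 3 is estimated as a number no higher from compound 1 to compound 3 (the limit leaves the size open), none beyond the scatter, and a limit rather than a number is again thought likely.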

Compound 3, minimum cytotoxic concentration: 100 ug/mL
For compound 3 the middle estimate is 5.0-fold (0.70 log units) below the measured one; the measured number lies above the stated range.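

In this assay compound 1 gives only a limit of the assay, >= 20 ug/mL and not a number, so no step to compound 3 can be read: the limit of >= 20 ug/mL in this assay, at which 1 of the 3 values shown sits.

The compounds shown leave open whether 2-hydroxyphenyl in place of 4-cyanophenyl shifts the minimum cytotoxic concentration at all on the shared core.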